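A few compounds are considered here, and "the series" means these few. Any claim that something is new, unique, unknown or untested is made for them only; others in the source may bear on it.

Measured so far in a functional assay on HL-60 cells (Homo sapiens) for inhibition, read by MTT assay, with a stated time of 72 h, tested at 50 uM; a lower number here means less inhibition of growth, a higher number more inhibition of growth at the concentration tested:
compound 1 `C=CCc1ccc(OCc2cn(-c3ccc(C#N)cc3)nn2)c(O)c1` — 31.8%
compound 2 `C=CCc1ccc(OCc2cn(-c3ccccc3CO)nn2)c(O)c1` — 47.1%

Among the measured compounds shown here, compound 1 stands at the lower of the two numbers in this assay; compound 2 sits above it, and the step of a number 15.3 percentage points higher from compound 1 to compound 2 (beyond the scatter) is the only measured step.

Compound 3 `C=CCc1ccc(OCc2cn(-c3ccc(C(=O)c4ccccc4)cc3)nn2)c(O)c1` is yet to be measured. It differs from compound 1 by benzoyl in place of cyano on an aromatic carbon. For the measured compounds named here, no measured step bears directly on this change: the single step known, from compound 1 to compound 2, exchanges the whole aryl on the aromatic nitrogen rather than one group on it, and it moved the number by only a modest amount. With nothing closer to lean on, the expected step of a number 6.2 percentage points higher from compound 1 to compound 3 (within the scatter) is small, at most modest upward, and may not exceed the scatter. Compound 3 is therefore estimated at 38% in this assay, with a range from 20% to 58%.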

Compound 3, percent growth inhibition at one concentration: 40.5%
Estimate against measurement, compound 3: 2.5 percentage points below, and the stated range covers the measured number.
By their numbers in this assay, from the lowest: compounds 1, 3 and 2 (each within the scatter of the next, the first and the last beyond it).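

Benzoyl in place of cyano on this aromatic carbon gives a number 8.7 percentage points higher from compound 1 to compound 3 (within the scatter) in this assay. Among the compounds shown here, this is the first measured change of a single group on the aryl rather than of the whole aryl, and it shows that a group of 8 heavy atoms carrying a six-membered aromatic ring can replace one of 2 heavy atoms here without a step beyond the scatter. No evidence at hand bears on what lies behind this result.

Still open, on these data alone, is whether an amine or a carboxylic acid on this same carbon would move the number beyond the scatter in this assay. Also open, as far as these compounds go, is whether a longer chain ending in a benzoyl carbonyl would give a similar number to that of compound 3.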